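The source may hold more compounds than are shown below. What is called first, only, known or untested is meant among the compounds shown, and "the series" means these compounds.

Compound 1 `CCCn1c(=O)[nH]c2nc(-c3ccc(S(=O)(=O)N4CCN(C)CC4)cc3)[nH]c2c1=O` is the reference point of this small set. In an assay on CHO cells for displacement of a labelled ligand from adenosine receptor A2b (Homo sapiens), read by scintillation counting, with a stated time of 75 min, in the presence of a further agent that is not named here (a higher number here means a weaker inhibitor, a lower number a stronger inhibitor), compound 1 gives 48.2 nM, the highest of the three numbers measured. Its two analogues replace the methyl on the ring amine nitrogen with an aryl group: compound 2 `CCCn1c(=O)[nH]c2nc(-c3ccc(S(=O)(=O)N4CCN(c5ccccc5Br)CC4)cc3)[nH]c2c1=O` gives 0.137 nM and compound 3 `CCCn1c(=O)[nH]c2nc(-c3ccc(S(=O)(=O)N4CCN(c5ccccc5Cl)CC4)cc3)[nH]c2c1=O` gives 0.403 nM. The corresponding steps are a 350-fold lower number from compound 1 to compound 2 (2.55 log units; beyond the scatter) and a 120-fold lower number from compound 1 to compound 3 (2.08 log units; beyond the scatter), both large; between the two halogens the step is a 2.9-fold higher number from compound 2 to compound 3 (0.47 log units; beyond the scatter).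

Compound 4 `CCCn1c(=O)[nH]c2nc(-c3ccc(S(=O)(=O)N4CCN(Cc5cccc(Br)c5)CC4)cc3)[nH]c2c1=O` differs from compound 1 as follows: 3-bromophenyl in place of hydrogen on a saturated chain carbon bound to an amine nitrogen in a ring. The change is related to, but not the same as, the two measured steps: the bromophenyl is attached through a saturated chain carbon rather than directly to the amine nitrogen, and the bromine sits as 3-bromophenyl rather than 2-bromophenyl. The large gains from compound 1 to compound 2 and to compound 3 suggest a lower number is expected, but the one-carbon spacer and the altered bromine position leave the size of the step uncertain. Compound 4 is therefore estimated at 2.5 nM, within 0.3 nM to 20 nM, an expected step of a 19-fold lower number from compound 1 to compound 4 (1.29 log units; beyond the scatter).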

Compound 4, inhibition constant: 0.148 nM
Estimate against measurement, compound 4: 17-fold (1.23 log units) above; measured number outside the range, below it.
By their numbers in this assay, from the lowest: compounds 2 and 4 (each within the scatter of the next); then compound 3; then compound 1.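

In this assay, the large gain over the methyl group does not require an aryl group directly on the amine nitrogen in a ring: 3-bromobenzyl in place of methyl gives a 330-fold lower number from compound 1 to compound 4 (2.51 log units; beyond the scatter), so a benzyl group is accepted here as well as a phenyl group. The step of a 1.1-fold higher number from compound 2 to compound 4 (0.03 log units; within the scatter) lies within the scatter, so 3-bromobenzyl and 2-bromophenyl cannot be told apart in this assay, whereas a 2.7-fold lower number from compound 3 to compound 4 (0.44 log units; beyond the scatter) is a modest step beyond it. Nothing shown gives a reason for these steps.

Compound 4 differs from compound 2 in both the attachment through a chain carbon and the place of the bromine, and the compounds shown do not separate these two changes. An unsubstituted benzyl group or a longer chain such as 2-phenylethyl on the same nitrogen would show how far the gain depends on the bromine and on the length of the link.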